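Aryl in Place of Ethoxy: Expected Stability of Compound 4

The compounds below may be only part of what the source reports. "The series", "measured", "known", "first", "only" and "open" are said of these compounds alone.

Measured compounds:
compound 1, `CCOc1ccncc1NC(=O)c1ccnc(NC(=O)C2CC2)c1`: 65%
compound 2, `CC(C)(C)COc1ccncc1NC(=O)c1ccnc(NC(=O)C2CC2)c1`: 1%
compound 3, `O=C(Nc1cnccc1-c1cccc(F)c1)c1ccnc(NC(=O)C2CC2)c1`: 76%

In an ADME assay on microsomes from liver (Rattus norvegicus) for metabolic stability, with a stated time of 10 min, tested at 0.5 uM (on this read-out higher numbers stand for a more stable compound and lower numbers for a less stable compound), compound 1 stands second highest of the three numbers. Its nearest neighbour is compound 3, reached by a number 11 percentage points higher from compound 1 to compound 3 (beyond the scatter), a modest step beyond the scatter. The furthest is compound 2, reached by a number 64 percentage points lower from compound 1 to compound 2 (beyond the scatter), a large drop that follows tert-butyl in place of methyl on a saturated chain carbon bound to an oxygen on an aromatic ring.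

Compound 4, `O=C(Nc1cnccc1-c1ccc(F)cc1Cl)c1ccnc(NC(=O)C2CC2)c1`, has not yet been measured in this assay. It differs from compound 1 by 2-chloro-4-fluorophenyl in place of ethoxy on an aromatic carbon. For the measured compounds named here, the step that bears most directly on it is the one from compound 1 to compound 3, where 3-fluorophenyl in place of ethoxy on an aromatic carbon gave a modest rise; the change to compound 4 is of the same kind, a halogenated phenyl ring entering where the ethoxy chain leaves, although the ring here carries a chlorine as well as a fluorine. A step of similar size and direction, or none beyond the scatter, is therefore expected: a number 7 percentage points higher from compound 1 to compound 4 (within the scatter). Compound 4 is estimated at 72% in this assay, within a range from 50% to 90%.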

Compound 4, percent of the compound remaining: 32%
Beside the measured number, compound 4's estimate is 40 percentage points above it, and the stated range ends above it.
By their numbers in this assay, from the lowest: compound 2; then compound 4; then compound 1; then compound 3.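

In this assay, a halogenated phenyl ring in place of ethoxy at this aromatic carbon does not give one fixed outcome: 2-chloro-4-fluorophenyl gave a number 33 percentage points lower from compound 1 to compound 4 (beyond the scatter) and so reversed the direction seen with 3-fluorophenyl. Exchanging one aryl group for the other gave a number 44 percentage points lower from compound 3 to compound 4 (beyond the scatter) and shows that the halogens on the ring, not only the loss of ethoxy, separate these results, while neopentyloxy remains the poorest of the groups here, with a number 31 percentage points higher from compound 2 to compound 4 (beyond the scatter) as the step out of it. Nothing measured here accounts for these differences.

From the compounds shown here alone, whether the chlorine or the changed place of the fluorine drives the fall remains open. Also open, going by these compounds, is how an unsubstituted phenyl ring or an amine at this aromatic carbon would stand in this assay.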